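The source may hold more compounds than are shown below. What is called first, only, known or untested is meant among the compounds shown, and "the series" means these compounds.

Measured compounds:
- compound 1, `N#Cc1c(-c2ccc(Br)cc2)nc2cnccc2c1NCC(N)=O`: in a physicochemical assay for lipophilicity, read by HPLC, at pH 7.5 (on this read-out lower numbers stand for lower lipophilicity and higher numbers for higher lipophilicity), compound 1 gives 1.9
- compound 2, `CCOc1ccccc1-c1ccc(-c2nc3cnccc3c(N[C@@H]3CCOC3=O)c2C#N)cc1`: in this assay compound 2 gives 2.7
- compound 3, `CC[C@@H](Nc1c(C#N)c(-c2ccc(-c3ccc(F)cc3)cc2)nc2cnccc12)C(N)=O`: in this assay compound 3 gives 2.7

Compound 3 stands level with compound 2 at the digits shown, the two together being the highest of the three numbers in this assay; the two values fall within the scatter of each other, so no order between them can be read. Compound 1 lies furthest from compound 3, its number being the lower of the two, a gap that is beyond the scatter.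

Compound 4, `CC[C@@H](Nc1c(C#N)c(-c2ccc(-c3cccc(C)c3F)cc2)nc2cnccc12)C(N)=O`, has not yet been measured. It differs from compound 3 in one place: 2-fluoro-3-methylphenyl in place of 4-fluorophenyl on an aromatic carbon. Among the compounds with values here, no pair of measured compounds differing by exactly this change exists, so the size of the step rests on the change alone. A small upward step in this assay is expected, of the order of the scatter or a little beyond it, since compound 3 already sits at 2.7 and the group that enters replaces a smaller one. The expected step is a number 0.30 log units higher from compound 3 to compound 4 (within the scatter). Compound 4 is estimated at 3, with a range from 2.6 to 3.4.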

Compound 4, distribution coefficient: 3
Estimate against measurement, compound 4: no gap at the digits printed; the range from low to high includes it.
By their numbers in this assay, from the lowest: compound 1; then compounds 2, 3 and 4 (each within the scatter of the next).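

In this assay, within the data shown here, the change at this aromatic carbon, para to a large group, from 4-fluorophenyl to 2-fluoro-3-methylphenyl, gives a number 0.30 log units higher from compound 3 to compound 4 (within the scatter) and so provides the first step that can be read at one place. The step stays inside the scatter, so this read-out does not tell the two aryl groups apart here, and no order can be set between the two compounds. Nothing available bears on the cause of a step of this size.

From the compounds shown here alone, whether this position would respond to a group of another kind, such as an amine or a carboxylic acid on the aryl ring, remains open. One pair also cannot show whether the same change would give a like step with a different side chain on the core.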